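From a Branched Amide to a Vinyl Amide

A few compounds are considered here, and "the series" means these few. Any claim that something is new, unique, unknown or untested is made for them only; others in the source may bear on it.

compound 1 `COc1ccc(CN(C(=O)C(C)Br)c2cc(OC)c(OC)c(OC)c2)cc1O` — 120 nM
compound 2 `COc1ccc(CN(C(=O)C(C)C)c2cc(OC)c(OC)c(OC)c2)cc1O` — 210 nM

In a functional assay on MGC-803 cells (Homo sapiens) for inhibition, read by MTT assay, with a stated time of 48 h (on this read-out lower numbers stand for stronger inhibition and higher numbers for weaker inhibition), compound 1 gives 120 nM and compound 2 gives 210 nM. Compound 2 has the higher of the two numbers, but the step of a 1.8-fold higher number from compound 1 to compound 2 (0.24 log units; within the scatter) leaves the two within the scatter. Compound 3 `C=CC(=O)N(Cc1ccc(OC)c(O)c1)c1cc(OC)c(OC)c(OC)c1` differs from compound 2 by vinyl in place of isopropyl on a carbonyl carbon. Among the compounds with values here, the only measured step, also a change of the group on the carbonyl carbon, was small, so a step of a 1.4-fold lower number from compound 2 to compound 3 (0.15 log units; within the scatter) within the scatter is expected. Compound 3 is estimated at 150 nM, between 50 nM and 450 nM.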

Compound 3, half-maximal inhibitory concentration: 62 nM
Compound 3: the middle estimate sits 2.4-fold (0.38 log units) above what was measured, and the stated range covers the measured number.
By their numbers in this assay, from the lowest: compounds 3, 1 and 2 (each within the scatter of the next, the first and the last beyond it).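

In this assay the group on the carbonyl carbon now shows an effect: a 3.4-fold lower number from compound 2 to compound 3 (0.53 log units; beyond the scatter) is a modest step, but the first beyond the scatter at this place. The vinyl and 1-bromoethyl groups remain unseparated, as a 1.9-fold lower number from compound 1 to compound 3 (0.29 log units; within the scatter) stays within the scatter, so only isopropyl is set apart from vinyl. Nothing available explains this difference. On these data alone, whether an ethyl group, which lacks the double bond, would match vinyl remains open. So does the outcome with a longer chain or an amine on this carbonyl carbon.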